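This account rests on a few compounds, and the source may have more. Where it says the series, first, only, none or still open, it means among the compounds named here.

In an in vivo ADME assay on the whole organism for pharmacokinetics, with Canis familiaris (Canis lupus familiaris) as the target (a lower number here means slower removal, a higher number faster removal of the compound), compound 1 (`Nc1noc2ccc(-n3nc(C(F)(F)F)c4c3C(=O)N(c3ccc(-c5ccccc5CN5CCCC5)cc3F)CC4)cc12`) gives 13.2 mL/min/kg as its measured value. Compound 2 (`Nc1noc2ccc(-n3nc(C(F)(F)F)c4c3C(=O)N(c3ccc(-c5ccccc5CN5CCCC5)cc3)CC4)cc12`) gives 16.8 mL/min/kg and compound 3 (`CN(C)Cc1ccccc1-c1ccc(N2CCc3c(C(F)(F)F)nn(-c4ccc5onc(N)c5c4)c3C2=O)cc1`) gives 16.3 mL/min/kg on the same scale. All three values lie within the scatter of one another, so compound 1 stands level with the other two.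

Compound 4 (`Nc1noc2ccc(-n3nc(C(F)(F)F)c4c3C(=O)N(c3ccc(-c5ccccc5CN5CC[C@@H](O)C5)cc3F)CC4)cc12`) differs from compound 1 by one change (hydroxy in place of hydrogen on a saturated ring carbon) in which hydroxy takes the place of hydrogen on a saturated ring carbon, so pyrrolidin-1-yl becomes 3-hydroxypyrrolidin-1-yl. Among the measured compounds shown here, two measured steps bear on this. Dimethylamino in place of that same pyrrolidin-1-yl gave a step (a 1.0-fold lower number from compound 2 to compound 3 (0.01 log units; within the scatter)) within the scatter, and hydrogen in place of fluoro on an aromatic carbon gave another (a 1.3-fold higher number from compound 1 to compound 2 (0.10 log units; within the scatter)) also within it. Neither step adds a hydroxy, so this particular change remains unmeasured.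

In this assay no step beyond the scatter is therefore expected, and the estimated step (a 1.1-fold lower number from compound 1 to compound 4 (0.02 log units; within the scatter)) is small, with no firm direction. Compound 4 is expected at 12.5 mL/min/kg with an estimated range from 7 mL/min/kg to 23 mL/min/kg in this measurement.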

Compound 4, clearance: 5.83 mL/min/kg
Estimate against measurement, compound 4: 2.1-fold (0.33 log units) above; the measured number lies below the stated range.
By their numbers in this assay, from the lowest: compound 4; then compounds 1, 3 and 2 (each within the scatter of the next).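

In this assay, among the compounds shown here, hydroxy in place of hydrogen on a saturated ring carbon, two ring bonds from the ring nitrogen, turns pyrrolidin-1-yl into 3-hydroxypyrrolidin-1-yl and gives the first step here beyond the scatter (a 2.3-fold lower number from compound 1 to compound 4 (0.35 log units; beyond the scatter)). The earlier steps, hydrogen in place of fluoro (a 1.3-fold higher number from compound 1 to compound 2 (0.10 log units; within the scatter)) and dimethylamino in place of pyrrolidin-1-yl (a 1.0-fold lower number from compound 2 to compound 3 (0.01 log units; within the scatter)), stayed within it, so this ring carbon is the one place shown where a single change clearly moves the number. Nothing measured in this set explains the fall.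

As far as these compounds go, it remains open whether a methoxy, an amine or a fluoro on that same ring carbon would give a similar step. Also open, from the compounds shown here alone, is whether the opposite mirror-image hydroxy, or the same hydroxy on compound 2, would do so.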